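The compounds below may be only part of what the source reports. "The series", "measured", "known", "first", "only" and "open" are said of these compounds alone.

Of the compounds shown here, three built on one shared core have been measured in a functional assay on HepG2 cells (Homo sapiens) for inhibition, read by MTT assay, with a stated time of 48 h; a lower number here means a stronger inhibitor, a higher number a weaker inhibitor. Compound 1 `Clc1ccccc1CSc1nnc(-c2ccncc2)n1-c1ccccc1` gives 15700 nM. Compound 2 `Clc1cccc(CSc2nnc(-c3ccncc3)n2-c2ccccc2)c1` gives 11200 nM, and compound 3 `Fc1ccc(CSc2nnc(-c3ccncc3)n2-c2ccccc2)c(F)c1` gives 10200 nM. Among these three numbers compound 2 stands second highest, with compound 3 nearest and compound 1 furthest, and both gaps lie within the scatter. The steps of a 1.4-fold lower number from compound 1 to compound 2 (0.15 log units; within the scatter), a 1.5-fold lower number from compound 1 to compound 3 (0.19 log units; within the scatter) and a 1.1-fold lower number from compound 2 to compound 3 (0.04 log units; within the scatter) each rearrange the substituents on the benzyl group, and none of them moves the number beyond the scatter.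

Compound 4 `c1ccc(CSc2nnc(-c3ccncc3)n2-c2ccccc2)cc1` has not yet been measured. The change from compound 2 to compound 4 is hydrogen in place of chloro on an aromatic carbon, placed on an aromatic carbon of a six-membered aromatic ring of carbon only, meta to a large group; cut one bond further out it reads 3-chlorophenyl to phenyl. Since the measured steps on this same group all stayed within the scatter, no step beyond the scatter is expected in this assay here either. Compound 4 is therefore estimated to give 12000 nM, with a range from 5000 nM to 28000 nM. The step of a 1.1-fold higher number from compound 2 to compound 4 (0.03 log units; within the scatter) that this estimate implies is expected to stay within the scatter.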

Compound 4, half-maximal inhibitory concentration: 12900 nM
For compound 4 the middle estimate is 1.1-fold (0.03 log units) below the measured one, within the range that was stated.
By their numbers in this assay, from the lowest: compounds 3, 2, 4 and 1 (each within the scatter of the next).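

Taking the chloro off entirely is a different test from the earlier swaps, which only exchanged one substituent pattern on the benzyl group for another. In this assay hydrogen in place of chloro gives a 1.2-fold higher number from compound 2 to compound 4 (0.06 log units; within the scatter) and, with the chloro at the other position, a 1.2-fold lower number from compound 1 to compound 4 (0.09 log units; within the scatter) while stripping both fluorines gives a 1.3-fold higher number from compound 3 to compound 4 (0.10 log units; within the scatter) and so leaves the plain phenyl within the scatter of all three substituted compounds. Among these four compounds, then, neither chloro nor fluoro on this ring has any effect on the number that can be told from scatter. No measurement available here speaks to why this position responds so little. Still open, as far as these compounds go, is whether an amine or a carboxylic acid on this ring, or a longer chain in place of the saturated chain carbon bound to the sulfur, would move the number beyond the scatter.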